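This account rests on a few compounds, and the source may have more. Where it says the series, first, only, none or still open, it means among the compounds named here.

Measured so far:
Compound 1, `Cc1cnc(N2CCC(c3coc4c(N5CCc6cc(S(C)(=O)=O)ccc65)ncnc34)CC2)nc1`: 145 mL.min-1.g-1
Compound 2, `CC(=O)c1cnc(N2CCC(c3coc4c(N5CCc6cc(S(C)(=O)=O)ccc65)ncnc34)CC2)nc1`: 154 mL.min-1.g-1
Compound 3, `CC(O)c1cnc(N2CCC(c3coc4c(N5CCc6cc(S(C)(=O)=O)ccc65)ncnc34)CC2)nc1`: 66 mL.min-1.g-1

In an ADME assay on microsomes from liver (Mus musculus) for pharmacokinetics (on this read-out higher numbers stand for fast clearance and lower numbers for slow clearance), compound 2 gives the highest of the three numbers; compound 1 sits within the scatter of it, while compound 3 lies beyond it, as a 2.3-fold lower number from compound 2 to compound 3 (0.37 log units; beyond the scatter) shows. Compound 4, `CS(=O)(=O)c1ccc2c(c1)CCN2c1ncnc2c(C3CCN(c4ncc(F)cn4)CC3)coc12`, differs from compound 2 in one place: fluoro in place of acetyl on an aromatic carbon. Among the compounds with values here, no measured step swaps acetyl for fluoro. The nearest guide is a 1.1-fold higher number from compound 1 to compound 2 (0.03 log units; within the scatter), where a small methyl and the acetyl gave numbers within the scatter, whereas a 2.3-fold lower number from compound 2 to compound 3 (0.37 log units; beyond the scatter) shows a hydroxyethyl lowering the number modestly. Fluoro is small and carries no hydroxyl, so compound 4 is expected to stay close to compound 2, with a 1.2-fold lower number from compound 2 to compound 4 (0.07 log units; within the scatter), within the scatter. The estimate for compound 4 is 130 mL.min-1.g-1, ranging from 65 mL.min-1.g-1 to 260 mL.min-1.g-1.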

Compound 4, intrinsic clearance in microsomes: 154 mL.min-1.g-1
Estimate against measurement, compound 4: 1.2-fold (0.07 log units) below; the measured number falls inside the stated range.
By their numbers in this assay, from the lowest: compound 3; then compounds 1, 2 and 4 (each within the scatter of the next).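

Replacing the acetyl with fluoro, a group of a single heavy atom, does not move the number in this assay, with no change at the digits printed from compound 2 to compound 4 (within the scatter), and methyl gives the same picture, with a 1.1-fold higher number from compound 1 to compound 4 (0.03 log units; within the scatter). Among these groups, only the 1-hydroxyethyl of compound 3 stands apart, with a 2.3-fold higher number from compound 3 to compound 4 (0.37 log units; beyond the scatter). Nothing available explains this behaviour.

From the compounds shown here alone, it remains open whether an amine or a carboxylic acid at this place would also bring the number down. A longer chain carrying a hydroxyl is equally unresolved.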